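The source may report more compounds than this note shows. Statements on the series, on what has been measured and on what is new or still open speak of the compounds shown alone.

The three compounds measured here share one core and differ only in the group on the aromatic amine nitrogen. Compound 1 `COc1ccc(Nc2nc(-c3cccc(F)c3)nc3ccc(F)cc23)cc1` gives 38600 nM in a functional assay on HL-60 cells (Homo sapiens) for cytotoxicity, read by MTT assay, with a stated time of 48 h; a lower number here means a stronger inhibitor, a higher number a weaker inhibitor. Compound 2 `Fc1ccc(Nc2nc(-c3cccc(F)c3)nc3ccc(F)cc23)cc1` gives only a limit in this assay, > 50000 nM. Compound 3 `Fc1cccc(-c2nc(Nc3ccc(Cl)cc3)c3cc(F)ccc3n2)c1` gives 45700 nM in this assay, and its nearest neighbour among the numbers shown is compound 1, the step being a 1.2-fold higher number from compound 1 to compound 3 (0.07 log units; within the scatter). The other steps are an at least 1.2-fold higher number from compound 1 to compound 2 (0.11 log units; that floor lies within the scatter) and an at least 1.0-fold lower number from compound 2 to compound 3 (0.03 log units; that floor lies within the scatter); none of them rises beyond the scatter, and one of the three values sits at the limit of > 50000 nM in this assay, at which 1 of the 3 values shown sits.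

Compound 4 `Fc1cccc(-c2nc(Nc3cccc(Cl)c3)c3cc(F)ccc3n2)c1` is not yet measured. It differs from compound 3 by 3-chlorophenyl in place of 4-chlorophenyl on a nitrogen on an aromatic ring. Within the data shown here, no measured step moves the chlorine around its ring, so the only guide is that every exchange on this aromatic amine so far has stayed within the scatter. Compound 4 is therefore expected to show no step beyond the scatter, a 1.0-fold lower number from compound 3 to compound 4 (0.01 log units; within the scatter), and its estimated value in this assay is 45000 nM, with a range from 20000 nM to 100000 nM.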

Compound 4, half-maximal inhibitory concentration: > 50000 nM
Compound 4: a limit, no number (the forecaster's own chance of this, stated with the estimate: 40%); middle value at least 1.1-fold (0.04 log units) from the limit.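

Moving the chlorine from 4-chlorophenyl to 3-chlorophenyl keeps the same atoms on the aromatic amine nitrogen and changes only how they are joined, and this gives an at least 1.0-fold higher number from compound 3 to compound 4 (0.03 log units; that floor lies within the scatter). Measured against the methoxy-bearing compound, the result is an at least 1.2-fold higher number from compound 1 to compound 4 (0.11 log units; that floor lies within the scatter), while the step between compound 2 and compound 4 cannot be read, as both values are limits. No readable step among these aryl groups on the nitrogen passes the scatter in this assay, and limits now make up a larger share of the set: the limit of > 50000 nM in this assay, at which 2 of the 4 values shown sit.

As far as these compounds go, it remains open whether a different group on this nitrogen, such as a phenyl ring carrying an amine or a carboxylic acid, or a longer chain, would give a clearly lower number. From the compounds shown here alone, how far compound 2 and compound 4 lie beyond their limits also remains open.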